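Swapping a urea end group for a chloro-trifluoromethyl benzamide

The source may report more compounds than this note shows. Statements on the series, on what has been measured and on what is new or still open speak of the compounds shown alone.

Compound 1 `Nc1ccc(NC(=O)NCCCCC(c2ccc(F)cc2)c2ccc(F)cc2)cc1` carries a long chain ending in a urea, and in a functional assay on MDA-MB-231 cells (Homo sapiens) for cytotoxicity, read by MTT assay, with a stated time of 48 h (on this read-out higher numbers stand for weaker inhibition and lower numbers for stronger inhibition), compound 1 gives > 20000 nM, which is a limit of the assay rather than a number. Compound 2 `Fc1ccc(C(CCCCOC2COC(c3ccccc3)OC2)c2ccc(F)cc2)cc1` is a relative with a cyclic acetal in place of the urea; in this assay compound 2 gives > 20000 nM, again only a limit. Compound 3 `O=S(=O)(c1ccc(Cl)c(C(F)(F)F)c1)N1CCN(CCCCC(c2ccc(F)cc2)c2ccc(F)cc2)CC1` places a sulfonyl piperazine on the same chain; in this assay compound 3 gives > 20000 nM, also a limit. Within the data shown here, all three values sit at the same point, namely (the limit of > 20000 nM in this assay, at which 3 of the 3 values shown sit), so no compound can be set above or below another.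

Compound 4 `O=C(NCCCCC(c1ccc(F)cc1)c1ccc(F)cc1)c1ccc(Cl)c(C(F)(F)F)c1` differs from compound 1 by 4-chloro-3-(trifluoromethyl)phenyl in place of (4-aminophenyl)amino on a carbonyl carbon. Among the measured compounds shown here, no measured pair shows what such a change does here, so the expected step from compound 1 to compound 4 is an at least 1.1-fold lower number from compound 1 to compound 4 (0.04 log units; that floor lies within the scatter), which is not beyond the scatter. In this assay compound 4 is estimated to give 18000 nM, within a range from 5000 nM to 40000 nM.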

Compound 4, half-maximal inhibitory concentration: 11700 nM
Compound 4: the middle estimate sits 1.5-fold (0.19 log units) above what was measured; measured number inside the range.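

With 4-chloro-3-(trifluoromethyl)phenyl in place of (4-aminophenyl)amino on the carbonyl carbon, this assay shows an at least 1.7-fold lower number from compound 1 to compound 4 (0.23 log units; that floor lies within the scatter). Compound 4 is therefore the first compound shown with a true reading instead of a limit, but the floor of this step does not clear the usual scatter, so no real gain can be claimed from it. The other compounds offer no number to set beside it: the limit of > 20000 nM in this assay, at which 3 of the 4 values shown sit.

From the compounds shown here alone, it stays open which part of the new group counts, the chlorine or the trifluoromethyl, and whether the two are needed together. Also open, going by these compounds, is what a plain phenyl or a pyridine ring on the same carbonyl carbon would do, or how a longer chain would change the reading of compound 4.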